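Para substituent swap on the benzoate of the shared core

A few compounds are considered here, and "the series" means these few. Any claim that something is new, unique, unknown or untested is made for them only; others in the source may bear on it.

Measured so far:
compound 1 `C=C1C(=O)[C@@]23C(=O)OC[C@]4(C(=O)CCC(C)(C)[C@H]4C=O)[C@@H]2CC[C@@H]1[C@H]3OC(=O)c1ccccc1`: 1920 nM
compound 2 `C=C1C(=O)[C@@]23C(=O)OC[C@]4(C(=O)CCC(C)(C)[C@H]4C=O)[C@@H]2CC[C@@H]1[C@H]3OC(=O)c1ccc(OC)cc1`: 1870 nM

Two esters of the shared core have been run in a functional assay on MGC-803 cells (Homo sapiens) for cytotoxicity, read by MTT assay, with a stated time of 72 h; a higher number here means a weaker inhibitor, a lower number a stronger inhibitor. Compound 1 gives 1920 nM and compound 2 gives 1870 nM; the step of a 1.0-fold lower number from compound 1 to compound 2 (0.01 log units; within the scatter) lies within the scatter, so compound 2 stands alongside compound 1 rather than apart from it. Compound 3 `C=C1C(=O)[C@@]23C(=O)OC[C@]4(C(=O)CCC(C)(C)[C@H]4C=O)[C@@H]2CC[C@@H]1[C@H]3OC(=O)c1ccc(Cl)cc1` carries the change (chloro in place of methoxy on an aromatic carbon). Among the measured compounds shown here, the only step that bears on it is a 1.0-fold lower number from compound 1 to compound 2 (0.01 log units; within the scatter), at the same aromatic carbon, and it was flat. No shift beyond the scatter is therefore expected for compound 3, an expected step of a 1.0-fold higher number from compound 2 to compound 3 (0.01 log units; within the scatter). The estimate for compound 3 in this assay is 1900 nM, range 900 nM to 4000 nM.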

Compound 3, half-maximal inhibitory concentration: 3120 nM
Compound 3: the middle estimate sits 1.6-fold (0.22 log units) below what was measured, within the range that was stated.
By their numbers in this assay, from the lowest: compounds 2, 1 and 3 (each within the scatter of the next).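

In this assay, the step of a 1.7-fold higher number from compound 2 to compound 3 (0.22 log units; within the scatter) and the step of a 1.6-fold higher number from compound 1 to compound 3 (0.21 log units; within the scatter) show that chloro at this aromatic carbon, para to a large group, also stays inside the scatter. Hydrogen, methoxy and chloro at this place therefore give numbers that cannot be told apart, and a halogen here has not separated from the other two groups. Nothing measured bears on a cause for this result.

From the compounds shown here alone, whether an amine, a carboxylic acid or a longer chain at this carbon would move the number beyond the scatter remains open.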